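Quinone series: methylsulfonyl for chloro at compound 3

A few compounds are considered here, and "the series" means these few. Any claim that something is new, unique, unknown or untested is made for them only; others in the source may bear on it.

Compound 1 `O=C1C(Cl)=C(Cl)C(=O)c2ncccc21` and compound 2 `NC1=C(Cl)C(=O)c2ncccc2C1=O` share one core; in a functional assay on HL-60 cells (Homo sapiens) for antiproliferative activity, read by MTT assay, with a stated time of 48 h (on this read-out higher numbers stand for weaker inhibition and lower numbers for stronger inhibition), compound 1 gives 31800 nM and compound 2 gives 3260 nM. Within the data shown here, the single measured step is a 9.8-fold lower number from compound 1 to compound 2 (0.99 log units; beyond the scatter). Among the measured compounds shown here, on these two numbers compound 2 stands lowest, with compound 1 as its only neighbour and that gap beyond the scatter.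

Compound 3 `CS(=O)(=O)C1=C(N)C(=O)c2cccnc2C1=O` differs from compound 2 by methylsulfonyl in place of chloro on a double-bonded ring carbon, on a double-bonded ring carbon of the six-membered non-aromatic ring, next to the ring atom that bears an amino group. For the measured compounds named here, no measured step bears directly on this exchange: the one step known, from compound 1 to compound 2, swaps chloro for amino, not chloro for methylsulfonyl, so it gives no direction for the present change. The step is therefore expected to stay within the scatter, with wide room either way, as a 1.2-fold higher number from compound 2 to compound 3 (0.09 log units; within the scatter). For compound 3 in this assay the estimate is 4000 nM, within 800 nM to 20000 nM.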

Compound 3, half-maximal inhibitory concentration: 4530 nM
Compound 3: the middle estimate sits 1.1-fold (0.05 log units) below what was measured, within the range that was stated.
By their numbers in this assay, from the lowest: compounds 2 and 3 (each within the scatter of the next); then compound 1.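

In this assay the exchange of chloro for methylsulfonyl gives a 1.4-fold higher number from compound 2 to compound 3 (0.14 log units; within the scatter) and so leaves the number unchanged within the scatter. On a double-bonded ring carbon next to the ring atom that bears an amino group, a single chlorine can thus give way to the larger methylsulfonyl group, with its two hydrogen-bond acceptors, without a readable shift, whereas the earlier exchange of chloro for amino gave a 9.8-fold lower number from compound 1 to compound 2 (0.99 log units; beyond the scatter) and lay beyond the scatter. Nothing on hand gives a reason for this flat result.

From the compounds shown here alone, with only chloro and methylsulfonyl at this carbon, it remains open whether a methoxy group, a dimethylamino group or a sulfonyl group with a longer chain would also leave the number in place. Also open, going by these compounds, is whether a methylamino group in place of the amino group would hold the number of compound 3 as well.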